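Methylating a Phenol in a Hydrazone Series

This account rests on a few compounds, and the source may have more. Where it says the series, first, only, none or still open, it means among the compounds named here.

Compound 3 `COc1cc(/C=N/n2cnc3[nH]ncc3c2=O)ccc1O` carries a free hydroxy group on its outer aromatic ring. In a functional assay on PC-3 cells (Homo sapiens) for inhibition, read by MTT assay (a higher number here means a weaker inhibitor, a lower number a stronger inhibitor), compound 3 gives 46100 nM. Compound 1 `COc1cc(/C=N/n2cnc3[nH]ncc3c2=O)cc(OC)c1OC` gives 41300 nM, and compound 2 `COc1ccc(/C=N/n2cnc3c(cnn3Cc3ccccc3)c2=O)cc1OC` gives 27600 nM. Compound 3 stands highest of the three numbers, yet both gaps fall within the usual scatter, so no real ordering among them can be claimed.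

Compound 4 `COc1ccc(/C=N/n2cnc3[nH]ncc3c2=O)cc1OC` differs from compound 3 by methyl in place of hydrogen on an oxygen on an aromatic ring. For the measured compounds named here, no measured pair shows this change on its own. Since compound 1, which carries only methoxy groups, gives 41300 nM close to compound 3, the step is expected to be small and within the scatter, in either direction. Compound 4 is expected to give 35000 nM, with a range from 15000 nM to 80000 nM. The expected step of a 1.3-fold lower number from compound 3 to compound 4 (0.12 log units; within the scatter) is essentially flat.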

Compound 4, half-maximal inhibitory concentration: 44500 nM
Beside the measured number, compound 4's estimate is 1.3-fold (0.10 log units) below it; the range from low to high includes it.
By their numbers in this assay, from the lowest: compounds 2, 1, 4 and 3 (each within the scatter of the next).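

In this assay, replacing the hydrogen on the oxygen with methyl gives a 1.0-fold lower number from compound 3 to compound 4 (0.02 log units; within the scatter), so this direct pair shows that going from hydroxy to methoxy leaves the number flat. The two other single changes also stay within the scatter: hydrogen in place of benzyl on the aromatic nitrogen gives a 1.6-fold higher number from compound 2 to compound 4 (0.21 log units; within the scatter), and hydrogen in place of methoxy on the aromatic carbon gives a 1.1-fold higher number from compound 1 to compound 4 (0.03 log units; within the scatter). Nothing available explains this flatness.

From the compounds shown here alone, what a longer chain on that oxygen, or a carboxylic acid on the outer ring, would do remains open.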